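Chloro added to the core of compound 1

The source may report more compounds than this note shows. Statements on the series, on what has been measured and on what is new or still open speak of the compounds shown alone.

Of the compounds shown here, three have been tested in a functional assay on PC-3 cells (Homo sapiens) for cytotoxicity, read by sulforhodamine B assay, with a stated time of 48 h; a lower number here means a stronger inhibitor of growth, a higher number a weaker inhibitor of growth. Compound 1 `ClCc1ccc(Cn2cnc3c(Cl)ncnc32)cc1` gives 4780 nM in this assay. It stands second highest of the three numbers. Its nearest neighbour is compound 3 `ClCc1cccc(Cn2cnc3c(Cl)nc(Cl)nc32)c1`, which gives 2390 nM; this pair lies within the scatter, so no order can be read from it. Furthest from it is compound 2 `ClCc1ccc(Cn2cnc3nc(Cl)nc(Cl)c32)cc1`, which gives 17800 nM and so a number beyond the scatter on the weaker side.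

The step now followed goes from compound 1 to compound 4 `ClCc1ccc(Cn2cnc3c(Cl)nc(Cl)nc32)cc1`. The change is chloro in place of hydrogen on an aromatic carbon of the shared core, between two ring nitrogen atoms. For the measured compounds named here, no measured pair shows this exact change on its own, so the size of the step cannot be computed from the data. Compound 3 carries the same dichloro core with a differently placed benzyl group and gives 2390 nM, a number within the scatter of compound 1. On that basis the step from compound 1 to compound 4 is expected to be small, a 1.6-fold lower number from compound 1 to compound 4 (0.20 log units; within the scatter), pointing if anywhere toward a lower number. Compound 4 is estimated at 3000 nM, within a range from 1000 nM to 9000 nM.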

Compound 4, concentration for 50% growth inhibition: 2690 nM
Estimate against measurement, compound 4: 1.1-fold (0.05 log units) above, and the stated range covers the measured number.
By their numbers in this assay, from the lowest: compounds 3, 4 and 1 (each within the scatter of the next); then compound 2.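

In this assay the step of chloro in place of hydrogen on an aromatic carbon of the shared core, between two ring nitrogen atoms, gives a 1.8-fold lower number from compound 1 to compound 4 (0.25 log units; within the scatter) and so stays small: this position takes a chlorine atom with no change that can be told from the scatter. For the compounds shown here, it is the first direct reading at this position, and it gives no sign that the added chloro either gains or loses growth inhibition. Compound 3 gives 2390 nM and compound 4 gives 2690 nM with the dichloro core in both, and these two numbers lie within the scatter of each other, while no measurement available bears on why this chloro leaves the number so little moved.

Open, on these data alone, is whether a different group at this same position, such as an amine, a methoxy group or a longer chain, would produce a step beyond the scatter. The compounds shown also leave open what replacing the chloromethyl group, for instance with a hydroxymethyl group, would do on this core.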